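Swapping a Pyrazole Group for a Non-Aromatic Ring

The source may report more compounds than this note shows. Statements on the series, on what has been measured and on what is new or still open speak of the compounds shown alone.

Among the measured compounds shown here, in a functional assay on NCI-H1993 cells (Homo sapiens) for inhibition, read by CCK-8 assay, with a stated time of 72 h (a lower number here means a stronger inhibitor, a higher number a weaker inhibitor), compound 2 (`OCCn1cc(-c2cnc3ncn(Cc4ccc5ncccc5c4)c3n2)cn1`) gives 2330 nM and this is the only number available so far, so it cannot yet be ranked against any other compound. A second compound, compound 1 (`Cc1cc2ncccc2cc1C(C)n1cnc2ncc(-c3ccncc3)nc21`), carries the entry "not determined" (no result reported) and offers no comparison. Next in line is compound 3 (`C1=C(c2cnc3ncn(Cc4ccc5ncccc5c4)c3n2)CCNC1`), which keeps the shared core of compound 2. On an aromatic carbon, the 1-(2-hydroxyethyl)-1H-pyrazol-4-yl group leaves and a six-membered non-aromatic ring enters in its place (a group of 6 heavy atoms (5 carbon, 1 nitrogen; one six-membered non-aromatic ring with 1 hetero atom) in place of a group of 8 heavy atoms (5 carbon, 2 nitrogen, 1 oxygen; one five-membered aromatic ring with 2 hetero atoms), on an aromatic carbon). For the measured compounds named here, no pair of measured compounds shows what a change of this kind does in this assay and any forecast is therefore loose. Starting from compound 2 at 2330 nM as the sole anchor, a small weakening is expected, although a result within the usual scatter would be no surprise. The estimated change is a 1.3-fold higher number from compound 2 to compound 3 (0.11 log units; within the scatter) and it remains a cautious guess. Compound 3 is expected at 3000 nM with an estimated range from 800 nM to 10000 nM once it is measured.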

Compound 3, half-maximal inhibitory concentration: 6660 nM
Estimate against measurement, compound 3: 2.2-fold (0.35 log units) below; the range from low to high includes it.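

Among the compounds shown here, replacing the 1-(2-hydroxyethyl)-1H-pyrazol-4-yl group with the six-membered non-aromatic ring gives the first readable step in this assay: a 2.9-fold higher number from compound 2 to compound 3 (0.46 log units; beyond the scatter). The number at this aromatic carbon therefore responds to the group placed there, although the step is modest, and the five-membered aromatic ring is not needed for compound 3 to give a measured value. Nothing measured alongside these compounds accounts for the step, and the swap changes the ring and removes the hydroxyethyl chain together, so the effects of these two changes cannot be told apart.

A pyrazole carrying a methyl group or a longer chain in place of the 2-hydroxyethyl chain would help separate the role of the chain from that of the ring, while a morpholine or a piperidine would test other non-aromatic rings at the same place. As far as these compounds go, compound 1 has no number, so its differences from compound 2 and compound 3 cannot be read, and what changes elsewhere on the shared core would do remains open.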